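Methoxy in place of chloro: expected step in the series

The compounds below may be only part of what the source reports. "The series", "measured", "known", "first", "only" and "open" are said of these compounds alone.

In a functional assay on A-431 cells (Homo sapiens) for cytotoxicity (a higher number here means a weaker inhibitor, a lower number a stronger inhibitor), compound 1 (`COc1cc(N)c(C(=N)Nc2cccc(Br)c2)cc1OC`) gives 300000 nM and compound 2 (`COc1cc(N)c(C(=N)Nc2cccc(Cl)c2)cc1OC`) gives 460000 nM in the same read-out. Compound 2 thus stands level with compound 1, the two values lying within the scatter of each other. The next compound, compound 3 (`COc1cccc(NC(=N)c2cc(OC)c(OC)cc2N)c1`), departs from compound 2 as follows: methoxy in place of chloro on an aromatic carbon, meta to a large group.

Within the data shown here, only one measured step bears on this change. That step, a 1.5-fold higher number from compound 1 to compound 2 (0.19 log units; within the scatter), is chloro in place of bromo and stays within the scatter. It covers two halogens only. Among the measured compounds shown here, no methoxy compound has been measured yet, so the data give no direction for the new group. In this assay no step beyond the scatter is expected. The expected change is a 1.2-fold lower number from compound 2 to compound 3 (0.06 log units; within the scatter) on this estimate. Compound 3 is estimated at 400000 nM with an expected range of 150000 nM to 1000000 nM in this read-out.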

Compound 3, half-maximal inhibitory concentration: 340000 nM
For compound 3 the middle estimate is 1.2-fold (0.07 log units) above the measured one; low and high end bracket the measured number.
By their numbers in this assay, from the lowest: compounds 1, 3 and 2 (each within the scatter of the next).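

Methoxy is the first group at this position, on an aromatic carbon meta to a large group, that is not a halogen, and in this assay it gives a 1.4-fold lower number from compound 2 to compound 3 (0.13 log units; within the scatter) and also a 1.1-fold higher number from compound 1 to compound 3 (0.05 log units; within the scatter) when set against bromo. Both steps lie within the scatter, so compounds 1, 2 and 3 stand level, and the position takes a group carrying a hydrogen-bond acceptor, which chloro lacks, with no step beyond the scatter in this read-out. Nothing beyond the values themselves bears on this flat picture.

The compounds shown leave open whether any group at this position can move the number beyond the scatter in this assay, since the set holds only chloro, bromo and methoxy; an amine, a carboxylic acid or a longer alkoxy chain such as butoxy would test that range. Also open, going by these compounds, is whether the same indifference holds at other places on this ring or on the shared core, as all three compounds differ at this one position only.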